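Butyl in Place of Hydroxy on the Side Chain

The source may report more compounds than this note shows. Statements on the series, on what has been measured and on what is new or still open speak of the compounds shown alone.

Compound 1 `CNc1nc(-c2ccccc2)nc2c1nnn2Cc1ccccc1F` gives 25000000 nM in an assay on isolated protein for binding affinity to adenosine receptor A1 (Bos taurus); a lower number here means a stronger inhibitor, a higher number a weaker inhibitor.
Compound 2 `CC(O)CNc1nc(-c2ccccc2)nc2c1nnn2Cc1ccccc1F` gives 4800000 nM.
Compound 3 `OCCNc1nc(-c2ccccc2)nc2c1nnn2Cc1ccccc1F` gives 54000000 nM.

Among these three, compound 3 stands highest, and both of its steps to the others lie beyond the scatter, so it is the weakest binder of the set. Compound 4 `CCCCCCNc1nc(-c2ccccc2)nc2c1nnn2Cc1ccccc1F` differs from compound 3 by one change: butyl in place of hydroxy on a saturated chain carbon, two bonds along the chain from a nitrogen on an aromatic ring. Among the compounds with values here, no measured step swaps the hydroxy for a carbon chain, so the expectation rests on neighbouring steps. Adding carbon to this chain lowered the number: a 5.2-fold lower number from compound 1 to compound 2 (0.72 log units; beyond the scatter), and removing a methyl raised it sharply: an 11-fold higher number from compound 2 to compound 3 (1.05 log units; beyond the scatter). Adding the hydroxymethyl alone moved the other way: a 2.2-fold higher number from compound 1 to compound 3 (0.33 log units; beyond the scatter). Taken together, more carbon on the chain and less hydroxy both point toward a lower number, so a drop beyond the scatter is expected, an 11-fold lower number from compound 3 to compound 4 (1.03 log units; beyond the scatter). Compound 4 is therefore estimated at 5000000 nM, with a range from 500000 nM to 50000000 nM.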

Compound 4, inhibition constant: 25000000 nM
Beside the measured number, compound 4's estimate is 5.0-fold (0.70 log units) below it; the range from low to high includes it.
By their numbers in this assay, from the lowest: compound 2; then compounds 1 and 4 (each within the scatter of the next); then compound 3.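

In this assay butyl in place of hydroxy gives a 2.2-fold lower number from compound 3 to compound 4 (0.33 log units; beyond the scatter) and so shows that this position accepts a long carbon chain with no hydroxy, though the shift is only modest. Carbon added here does not by itself lower the number, since pentyl in place of hydrogen gives no change at the digits printed from compound 1 to compound 4 (within the scatter) and leaves the short and long chains within the scatter of each other. The 1-hydroxyethyl group keeps its lead over the long chain, as pentyl in its place gives a 5.2-fold higher number from compound 2 to compound 4 (0.72 log units; beyond the scatter) and shows that a hydroxy on the chain is not always a drawback.

On these data alone, it remains open whether a longer chain, or an amine at the end of the hexyl chain, would move the number further. Nothing available here explains these shifts.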